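The source may hold more compounds than are shown below. What is called first, only, known or untested is meant among the compounds shown, and "the series" means these compounds.

Compound 1 `CCCCCC(=O)c1ccc(CN(CCCCCCC(=O)O)S(C)(=O)=O)cc1` in an assay on HEK293 cells for inhibition of prostaglandin E2 receptor EP4 subtype (Rattus norvegicus) (on this read-out higher numbers stand for weaker inhibition and lower numbers for stronger inhibition), gives > 3200 nM, which is a limit rather than a number. Compound 2 `CCCCC(O)c1ccc(CN(CCCCCCC(=O)O)S(C)(=O)=O)cc1` gives > 3200 nM, also a limit. Compound 3 `CS(=O)(=O)N(CCCCCCC(=O)O)Cc1ccc(-c2ccccc2)cc1` gives > 3200 nM, again a limit.

Compound 3 thus stands at the limit of > 3200 nM in this assay, at which 3 of the 3 values shown sit, alongside the other two. Compound 4 `CCCCCC(O)c1ccc(CN(CCCCCCC(=O)O)S(C)(=O)=O)cc1` differs from it in one place: 1-hydroxyhexyl in place of phenyl on an aromatic carbon. The measured steps that bear on this change, a step that the two limits leave unreadable from compound 2 to compound 3, a step that the two limits leave unreadable from compound 1 to compound 3 and a step that the two limits leave unreadable from compound 1 to compound 2, have no readable size, both ends of each being limits. No direction beyond the scatter can therefore be expected in this assay. The estimate for compound 4 is 5000 nM, with a range from 2000 nM to 20000 nM. The step expected from compound 3 to compound 4 is accordingly a step that the limit leaves unreadable from compound 3 to compound 4.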

Compound 4, half-maximal inhibitory concentration: > 3200 nM
Compound 4: only a limit was reported; the forecaster's own chance of this, stated with the estimate: 70%; the middle value is on the limit's open side.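

Compound 4 also gives only a limit, so no step linking it to compound 1, compound 2 or compound 3 can be read: the limit of > 3200 nM in this assay, at which 4 of the 4 values shown sit.

The compounds shown leave open how strongly in this assay any of the four inhibits, and whether their different groups change that.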